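Toward compound 3: clearance known only as limits

A few compounds are considered here, and "the series" means these few. Any claim that something is new, unique, unknown or untested is made for them only; others in the source may bear on it.

Measured in an ADME assay on microsomes from liver (Homo sapiens) for metabolic stability; on this read-out higher numbers stand for fast clearance and lower numbers for slow clearance:
Compound 1 (`CCCC(Oc1ccc(-n2cc(OC)cn2)cc1)c1ccc(C(=O)NCCC(=O)O)cc1`) gives < 8 mL/min/kg as a limit
Compound 2 (`CCCC(Oc1ccc(-n2cc(C(F)(F)F)c(C)n2)cc1)c1ccc(C(=O)NCCC(=O)O)cc1`) gives < 10 mL/min/kg as a limit

Compound 2 stands at < 10 mL/min/kg in this assay as a limit and not a number. Compound 1 likewise gives only a limit, < 8 mL/min/kg and no number.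

Compound 3 (`CCCC(Oc1ccc(-n2cc(C#N)cn2)cc1)c1ccc(C(=O)NCCC(=O)O)cc1`) differs from compound 2 by 4-cyano-1H-pyrazol-1-yl in place of 3-methyl-4-(trifluoromethyl)-1H-pyrazol-1-yl on an aromatic carbon. Among the compounds with values here, the one measured step at this place is a step that the two limits leave unreadable from compound 1 to compound 2 and it offers no size to carry over. Compound 1 and compound 2 carry different groups here and both returned limits, so no step beyond the scatter is expected in this assay and no direction can be named. The expected change is a step that the limit leaves unreadable from compound 2 to compound 3 in this estimate. Compound 3 is estimated at 7 mL/min/kg in this assay, with an expected range from 3 mL/min/kg to 14 mL/min/kg and a good chance that a limit is reported again.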

Compound 3, clearance: < 8 mL/min/kg
Compound 3 was reported as a limit; the forecaster's own chance of this, stated with the estimate: 70%; the middle value lies beyond the limit too.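

In this assay, compound 1, compound 2 and compound 3 all return limits and no numbers, and the steps among them cannot be read. The compounds shown leave open whether clearance differs at all among the 4-methoxy-1H-pyrazol-1-yl, 3-methyl-4-(trifluoromethyl)-1H-pyrazol-1-yl and 4-cyano-1H-pyrazol-1-yl groups, and in which direction.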